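A Furan for a Thiophene on an Inactive Core

A few compounds are considered here, and "the series" means these few. Any claim that something is new, unique, unknown or untested is made for them only; others in the source may bear on it.

Of the compounds shown here, two have been tested in an assay on cells for inhibition of Lysyl oxidase homolog 4 (Homo sapiens), read by fluorescence, with stated times of 30 min and 1 h; a higher number here means a weaker inhibitor, a lower number a stronger inhibitor. Compound 1 `CC(C)(C)C1=NN(c2ccccc2)C(=O)C1` gives only a limit there, > 100000 nM, which is the edge of what the test can report and not a number. Compound 2 `O=c1c2ccc(-c3cccs3)nc2[nH]n1-c1ccccc1` likewise gives only a limit in this assay, > 100000 nM. Both values therefore sit at the limit of > 100000 nM in this assay, at which 2 of the 2 values shown sit, so compound 2 stands at the weak end of everything measured here, and no ordering between compound 1 and compound 2 can be drawn.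

Compound 3 `Cc1cc(-c2ccc3c(=O)n(-c4ccccc4)[nH]c3n2)c(C)o1` has not yet been measured. It differs from compound 2 in one place: 2,5-dimethylfuran-3-yl in place of thiophen-2-yl on an aromatic carbon. Among the measured compounds shown here, no step between measured compounds is available to show what such a swap does. The step from compound 2 to compound 3, a number no higher from compound 2 to compound 3 (the limit leaves the size open), is expected to stay within the usual scatter. Compound 3 is therefore estimated at 100000 nM in this assay, in a range from 30000 nM to 300000 nM, most likely again reported only as a limit.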

Compound 3, half-maximal inhibitory concentration: 55000 nM
For compound 3 the middle estimate is 1.8-fold (0.26 log units) above the measured one; low and high end bracket the measured number.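

Placing 2,5-dimethylfuran-3-yl in place of thiophen-2-yl on this aromatic carbon, next to the ring nitrogen, gives in this assay an at least 1.8-fold lower number from compound 2 to compound 3 (0.25 log units; that floor lies within the scatter). This shows that the position can carry a larger five-membered aromatic ring with two methyl groups while the assay still returns a number, the first in this set that is not a limit, although that number marks only very weak inhibition. The true size of the step remains unknown because compound 2 gives only a limit: the limit of > 100000 nM in this assay, at which 2 of the 3 values shown sit.

The compounds shown do not separate the effect of exchanging sulfur for oxygen in the ring from that of adding the two methyl groups. They also leave open how an aminomethyl group or a carboxylic acid on the five-membered ring would read in this assay.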